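Benzoxaborole pyrrole ketones: thiophene in place of methoxyphenyl

This account rests on a few compounds, and the source may have more. Where it says the series, first, only, none or still open, it means among the compounds named here.

Measured compounds:
compound 1, `OB1OCc2ccc(-n3cccc3)cc21`: > 10 ug/mL
compound 2, `COc1ccccc1C(=O)c1ccn(-c2ccc3c(c2)B(O)OC3)c1`: > 10 ug/mL

In an ADME assay on L929 cells (Mus musculus) for cytotoxicity, read by resazurin assay, with a stated time of 72 h (a lower number here means a stronger inhibitor, a higher number a weaker inhibitor), compound 2 gives > 10 ug/mL, which is a limit of the assay and not a number. Compound 1 likewise stops at a limit, so both values shown sit at the limit of > 10 ug/mL in this assay, at which 2 of the 2 values shown sit. Compound 3, `O=C(c1ccn(-c2ccc3c(c2)B(O)OC3)c1)c1cccs1`, is not yet measured. It differs from compound 2 as counted in thiophen-2-yl in place of 2-methoxyphenyl on a carbonyl carbon. For the measured compounds named here, no step between measured compounds is known, so the step expected from compound 2 to compound 3 in this assay is none beyond the scatter, with the value again likely a limit. Compound 3 is estimated at 20 ug/mL, between 8 ug/mL and 60 ug/mL, a step that the limit leaves unreadable from compound 2 to compound 3.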

Compound 3, half-maximal inhibitory concentration: > 10 ug/mL
Compound 3: only a limit was reported; the forecaster's own chance of this, stated with the estimate: 80%; the middle value lies beyond the limit too.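

In this assay no step can be read from compound 2 to compound 3 or from compound 1 to compound 3, because each value is a limit and not a number: the limit of > 10 ug/mL in this assay, at which 3 of the 3 values shown sit. The compounds shown leave open how far apart their cytotoxicities lie, and whether thiophen-2-yl in place of 2-methoxyphenyl changes it at all.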